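Swapping the pyrimidine for a pyridine on the sulfonamide

The source may report more compounds than this note shows. Statements on the series, on what has been measured and on what is new or still open speak of the compounds shown alone.

Measured so far:
- compound 1 `Cc1cc(C)nc(NS(=O)(=O)c2ccc(N3C(=O)/C(=C/c4coc5ccccc5c4=O)N=C3c3ccccc3)cc2)n1`: 63200 nM
- compound 2 `Cc1cc(C)nc(NS(=O)(=O)c2ccc(N3C(=O)/C(=C/c4coc5ccccc5c4=O)N=C3c3ccc(Cl)cc3)cc2)n1`: 52600 nM

In a functional assay on A549 cells (Homo sapiens) for cytotoxicity, read by sulforhodamine B assay, with a stated time of 72 h (on this read-out higher numbers stand for weaker inhibition and lower numbers for stronger inhibition), compound 1 gives 63200 nM. That is the larger of the two numbers seen so far, but the gap to compound 2, a 1.2-fold lower number from compound 1 to compound 2 (0.08 log units; within the scatter), is within the scatter, so the two compounds cannot be told apart on this read-out.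

Compound 3 `O=C1/C(=C/c2coc3ccccc3c2=O)N=C(c2ccccc2)N1c1ccc(S(=O)(=O)Nc2ccccn2)cc1` has not yet been measured. It differs from compound 1 in one place: pyridin-2-yl in place of 4,6-dimethylpyrimidin-2-yl on a sulfonamide nitrogen. Among the compounds with values here, the only measured step, from compound 1 to compound 2, concerns a chloro in place of hydrogen on an aromatic carbon elsewhere in the molecule and says nothing about the group on the sulfonamide nitrogen. Within the data shown here, with no measured step bearing on this change, the expectation is a step of a 1.1-fold lower number from compound 1 to compound 3 (0.02 log units; within the scatter), that is, nothing beyond the scatter. Compound 3 is therefore estimated at 60000 nM in this assay, with a range from 25000 nM to 150000 nM.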

Compound 3, half-maximal inhibitory concentration: > 100000 nM
Compound 3 ended at the assay's limit; the forecaster's own chance of this, stated with the estimate: 15%; at least 1.6-fold (0.22 log units) between middle value and limit.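

Within the data shown here, the group on the sulfonamide nitrogen had not been varied in the earlier compounds, and this first change there brings no gain in inhibition. In this assay, among these compounds, compound 3 reads > 100000 nM, which is a limit of the assay and not a number, and it is the only one of the values shown that sits there: the limit of > 100000 nM in this assay, at which 1 of the 3 values shown sits. Going by these compounds, the change can therefore be given only as a floor, an at least 1.5-fold higher number from compound 1 to compound 3 (0.19 log units; that floor lies within the scatter), so a real loss cannot be claimed from this step, and its true size stays unknown.

A plain pyrimidin-2-yl group, without the two methyl groups, would help separate the part played by those methyl groups from that of the second ring nitrogen. On these data alone, it also remains open whether an acetyl group or a small amine-bearing chain at this position would give a number well clear of the limit.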